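This account rests on a few compounds, and the source may have more. Where it says the series, first, only, none or still open, it means among the compounds named here.

Compounds measured so far:
- compound 1, `CC(C)(C)c1ccc(CN(O)/C(S)=N/Cc2ccc(NS(C)(=O)=O)c(F)c2)cc1`: 800 nM
- compound 2, `COc1cc(C/N=C(\S)N(O)Cc2ccc(C(C)(C)C)cc2)ccc1NS(C)(=O)=O`: 926 nM

Both compounds were tested in an assay on CHO cells for binding affinity to transient receptor potential cation channel subfamily V member 1 (Rattus norvegicus); on this read-out lower numbers stand for stronger inhibition and higher numbers for weaker inhibition. Compound 1 gives 800 nM in this assay, and compound 2 gives 926 nM. Going by the values given here, the only measured step, a 1.2-fold higher number from compound 1 to compound 2 (0.06 log units; within the scatter), is a swap of methoxy for fluoro on an aromatic carbon. Compound 2 therefore sits at the higher of the two numbers, but its distance to compound 1 is within the scatter, so the two cannot be told apart.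

Compound 3, `CC(C)(C)c1ccc(CN(O)/C(S)=N/Cc2ccc(NS(C)(=O)=O)c(Cl)c2)cc1`, is not yet measured. It differs from compound 2 in one place: chloro in place of methoxy on an aromatic carbon, on an aromatic carbon of a six-membered aromatic ring of carbon only, ortho to a methanesulfonamido group and meta to a large group. Among the compounds with values here, the only step that bears on this position is the one from compound 1 to compound 2, which stayed within the scatter. A halogen is already represented by compound 1 at 800 nM, and methoxy by compound 2 at 926 nM, with no separation between them.

On that basis compound 3 is expected to stay close to its neighbours, with a step of a 1.2-fold lower number from compound 2 to compound 3 (0.09 log units; within the scatter) that is not expected to exceed the scatter. The estimate for compound 3 in this assay is 750 nM, within a range of 350 nM to 1600 nM.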

Compound 3, inhibition constant: 1310 nM
Beside the measured number, compound 3's estimate is 1.7-fold (0.24 log units) below it; measured number inside the range.
By their numbers in this assay, from the lowest: compounds 1, 2 and 3 (each within the scatter of the next).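

In this assay, the two new steps cover chloro in place of methoxy (a 1.4-fold higher number from compound 2 to compound 3 (0.15 log units; within the scatter)) and chloro in place of fluoro (a 1.6-fold higher number from compound 1 to compound 3 (0.21 log units; within the scatter)), and both stay within the scatter. Going by these compounds alone, the aromatic carbon ortho to a methanesulfonamido group has now carried three different substituents, and no pair among them can be told apart on this read-out, so a second halogen separates neither from the first halogen nor from methoxy. No independent data are available to explain this lack of separation.

Going by these compounds, it remains open whether the number would stay within the scatter with a group of another kind on this carbon, such as an amine, a carboxylic acid or a longer alkoxy chain, or with a plain hydrogen. The three compounds also differ only at this one position, so they leave open whether a change elsewhere on the shared core would move the number beyond the scatter.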